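The source may hold more compounds than are shown below. What is called first, only, known or untested is meant among the compounds shown, and "the series" means these compounds.

Compound 1 `COc1ccc(C(F)(F)F)cc1NC(=O)CN1CCN(S(=O)(=O)N2CCC(C)CC2)CC1` carries a trifluoromethyl group and a methoxy group on its aromatic ring. In an assay on HEK293 cells for inhibition of potassium channel subfamily T member 1 (Homo sapiens), read by thallium flux (on this read-out lower numbers stand for stronger inhibition and higher numbers for weaker inhibition), compound 1 gives 2400 nM. Compound 3 `COc1ccc(Cl)cc1NC(=O)[C@@H](C)N1CCN(S(=O)(=O)N2CCC(C(F)(F)F)CC2)CC1` differs from compound 1 in several places at once, and in this assay compound 3 gives 3500 nM; the two numbers lie within the usual scatter of repeated measurements, so no difference between them can be claimed. Compound 2 `CCCC1CCN(C(=O)N2CCN(S(=O)(=O)N3CCN(CC(=O)Nc4cc(Cl)ccc4OC)CC3)CC2)CC1` gives only a limit of the assay, > 10000 nM in this assay, the limit described in the limit of > 10000 nM in this assay, at which 1 of the 3 values shown sits. Compound 1 thus stands alongside compound 3 among the numbers actually measured, the two not distinguishable here, while compound 2 reports no number at all.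

Compound 4 `COc1ccc(Br)cc1NC(=O)CN1CCN(S(=O)(=O)N2CCC(C)CC2)CC1` is not yet measured. It differs from compound 1 in one place: bromo in place of trifluoromethyl on an aromatic carbon. Among the compounds with values here, no measured pair in this set changes that position alone, so no measured step is available to guide the expectation, and the two other compounds offer no closer comparison. The expected step of a 1.0-fold higher number from compound 1 to compound 4 (0.02 log units; within the scatter) is no change beyond the scatter. Compound 4 is therefore expected to give about 2500 nM in this assay, with a likely range from 1000 nM to 6500 nM.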

Compound 4, half-maximal inhibitory concentration: 1400 nM
The estimate for compound 4 lay 1.8-fold (0.25 log units) above the measured number; the range from low to high includes it.
By their numbers in this assay, from the lowest: compounds 4, 1 and 3 (each within the scatter of the next, the first and the last beyond it). At a limit, above all of these: compound 2.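

In this assay, within the data shown here, bromo in place of trifluoromethyl on this aromatic carbon, para to a methoxy group, gives a 1.7-fold lower number from compound 1 to compound 4 (0.23 log units; within the scatter) and is the first step in the set that changes this position alone. Trifluoromethyl has 4 heavy atoms and bromo has 1, yet this exchange produces no difference that can be claimed, so in the setting of compound 1 the two groups cannot be told apart at this position. The data at hand hold no measurement that bears on why these two groups read alike.

From the compounds shown here alone, it remains open whether this position would accept a group of a different kind, such as an amine, a carboxylic acid or a longer chain, with as little effect on the number as this exchange had. A single step also cannot show whether bromo and trifluoromethyl would still read alike if another part of the shared core were changed.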